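The source may report more compounds than this note shows. Statements on the series, on what has been measured and on what is new or still open speak of the compounds shown alone.

Compound 1 `CCCCNC(=O)c1cc(OC)n(-c2ccccc2)n1` gives 20.6% in a functional assay on the whole organism (strain Wistar) for inhibition, with Rattus norvegicus as the target, read by paw edema, with stated times of 30 min and 3 h, at a dose of 100 mg/kg by the oral route; on this read-out lower numbers stand for less inhibition and higher numbers for more inhibition at the one dose given (going by the name of the read-out).
Compound 2 `COc1cc(C(=O)NC(C)C)nn1-c1ccccc1` gives 24.8%.
Compound 3 `CCCCOc1cc(C(=O)NCC)nn1-c1ccccc1` gives 0%.

Compound 3 stands lowest of the three numbers in this assay. Compound 1 is nearest to it and compound 2 furthest, and both gaps lie beyond the scatter. Compound 3 differs from compound 1 and from compound 2 in more than one place, so only the bare values of those pairs can be set side by side.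

Compound 4 `CCCCOc1cc(C(=O)N2CCCC2)nn1-c1ccccc1` has not yet been measured. The change from compound 3 is pyrrolidin-1-yl in place of ethylamino on a carbonyl carbon. Among the compounds with values here, the one measured step that alters the group on the amide-type nitrogen is a number 4.2 percentage points higher from compound 1 to compound 2 (within the scatter), a step within the scatter. Within the data shown here, no measured step replaces the hydrogen-bond donor on that nitrogen with a ring, so that part of the change has no precedent. On the evidence at hand the step is expected to be a number 5 percentage points higher from compound 3 to compound 4 (within the scatter), none beyond the scatter, in this assay. Compound 4 is therefore estimated at 5%, with a range from 0% to 20%.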

Compound 4, a percentage reported as inhibition, in the whole organism at one dose (the size of the read-out at that dose, not a potency): 17.6%
Compound 4: the middle estimate sits 12.6 percentage points below what was measured, and the stated range covers the measured number.
By their numbers in this assay, from the lowest: compound 3; then compounds 4, 1 and 2 (each within the scatter of the next).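

Pyrrolidin-1-yl in place of ethylamino on a carbonyl carbon gives in this assay a number 17.6 percentage points higher from compound 3 to compound 4 (beyond the scatter) and so takes the series away from a value of no measurable inhibition. Within the data shown here, the earlier change on an amide-type nitrogen, a number 4.2 percentage points higher from compound 1 to compound 2 (within the scatter) and on a different compound pair, showed no effect beyond the scatter, so this is the first step at that nitrogen to exceed it. The change removes the amide hydrogen and adds a five-membered non-aromatic ring at once, and nothing measured here explains the step or separates those two parts.

The compounds shown leave open whether the ring or the missing amide hydrogen goes with the higher number. A diethylamino group would keep the amide without that hydrogen and without a ring, while cyclopentylamino would keep both the hydrogen and a ring.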